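A few compounds are considered here, and "the series" means these few. Any claim that something is new, unique, unknown or untested is made for them only; others in the source may bear on it.

Compound 1 `Cc1ccc(-c2cn(CCCO)nn2)cc1`: > 100000 nM
Compound 2 `COc1ccc(C(O)c2cn(Cc3cccc(OC)c3)nn2)cc1`: > 100000 nM
Compound 3 `COc1ccc(-c2cn(CCCO)nn2)cc1`: > 100000 nM

All three compounds were examined in a functional assay on B16 cells (Mus musculus) for cytotoxicity, read by MTT assay, with a stated time of 48 h; a lower number here means a stronger inhibitor, a higher number a weaker inhibitor. For compound 1 the value recorded is a limit of the assay, not a number. The same is true for compound 2. The same is true for compound 3. The picture is summed up by the limit of > 100000 nM in this assay, at which 3 of the 3 values shown sit.

Compound 3 and compound 1 differ in one place, (methyl in place of methoxy on an aromatic carbon), and the step between them, a step that the two limits leave unreadable from compound 3 to compound 1, cannot be sized because both compounds sit at the limit. Compound 2 and compound 3 differ in more than one place, and the difference between the two cores is not broken down here.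

Compound 4 `COc1cccc(Cn2cc(C(O)c3ccc(C)cc3)nn2)c1` has not yet been measured in this assay. It differs from compound 2 by methyl in place of methoxy on an aromatic carbon. Among the compounds with values here, this is the same kind of change as the one from compound 3 to compound 1, though not the same: in compound 3 the place is para to a group of 9 heavy atoms, while in compound 2 it is para to a large group.

Within the data shown here, compound 2 shows only the limit > 100000 nM in this assay, and the one measured step of this kind is unreadable, so there is no measured ground for a shift. From compound 2, the step expected is a step that the limit leaves unreadable from compound 2 to compound 4. Compound 4 is therefore estimated at 150000 nM, within a range from 50000 nM to 500000 nM, with a strong chance that this assay again reports only its limit.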

Compound 4, half-maximal inhibitory concentration: > 100000 nM
Compound 4 was reported as a limit (the forecaster's own chance of this, stated with the estimate: 85%); the middle value does not contradict the limit.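

Within the data shown here, compound 2 and compound 4 both stand at a limit of this assay, and the step between them, methyl in place of methoxy on an aromatic carbon, cannot be read, so these compounds yield no new step. The compounds shown leave open whether the change from 4-methoxyphenyl to 4-methylphenyl, or any other difference among them, has a measurable effect, with the whole set resting on one value: the limit of > 100000 nM in this assay, at which 4 of the 4 values shown sit.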